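A few compounds are considered here, and "the series" means these few. Any claim that something is new, unique, unknown or untested is made for them only; others in the source may bear on it.

Three compounds share one core and differ only in the group on one aromatic carbon. Compound 1 `Cc1cc(SC(C)(C)C)c(S(C)(=O)=O)cc1C(=O)N=C(N)N` gives 22 nM in a functional assay for inhibition of sodium/hydrogen exchanger (Oryctolagus cuniculus); a higher number here means a weaker inhibitor, a lower number a stronger inhibitor; compound 2 `Cc1cc(Sc2ccncc2)c(S(C)(=O)=O)cc1C(=O)N=C(N)N` gives 13 nM; compound 3 `CCOc1cc(C)c(C(=O)N=C(N)N)cc1S(C)(=O)=O` gives 19 nM. Compound 3 stands second highest of the three numbers, although all three lie within the usual scatter of one another. Compound 4 `Cc1cc(-n2cccn2)c(S(C)(=O)=O)cc1C(=O)N=C(N)N` differs from compound 3 by 1H-pyrazol-1-yl in place of ethoxy on an aromatic carbon. Among the measured compounds shown here, the steps that bear on this are the earlier exchanges at the same aromatic carbon, a 1.2-fold lower number from compound 1 to compound 3 (0.06 log units; within the scatter) and a 1.5-fold higher number from compound 2 to compound 3 (0.16 log units; within the scatter), both within the scatter. Exchanging the group at this carbon has so far moved nothing beyond the scatter, so the step of a 1.1-fold higher number from compound 3 to compound 4 (0.02 log units; within the scatter) is expected to be no larger than the scatter. Compound 4 is therefore estimated at 20 nM, between 8 nM and 50 nM.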

Compound 4, half-maximal inhibitory concentration: 25 nM
Compound 4: the middle estimate sits 1.3-fold (0.10 log units) below what was measured; the measured number falls inside the stated range.
By their numbers in this assay, from the lowest: compounds 2, 3, 1 and 4 (each within the scatter of the next).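

With 1H-pyrazol-1-yl, an aromatic ring now sits on this carbon, ortho to the methylsulfonyl group, and a 1.3-fold higher number from compound 3 to compound 4 (0.12 log units; within the scatter) and a 1.9-fold higher number from compound 2 to compound 4 (0.28 log units; within the scatter) and also a 1.1-fold higher number from compound 1 to compound 4 (0.06 log units; within the scatter) all stay small. Ethoxy, two sulfanyl groups and this five-membered ring have therefore all been exchanged here without any step beyond the scatter. No measurement shown explains this tolerance. Still open, on these data alone, is whether an amine, a carboxylic acid or a longer alkoxy chain on this carbon would give a step beyond the scatter.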